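This account rests on a few compounds, and the source may have more. Where it says the series, first, only, none or still open, it means among the compounds named here.

For the measured compounds named here, in an ADME assay on microsomes from liver (Rattus norvegicus) for metabolic stability (on this read-out lower numbers stand for a less stable compound and higher numbers for a more stable compound), compound 2 `C/C(=C/CN)CN(C[C@H]1Cc2ccccc2CN1)[C@H]1CCCc2cccnc21` gives 2% as the lower of the two numbers so far, and compound 1 `N[C@H]1CC[C@H](N(C[C@H]2Cc3ccccc3CN2)[C@H]2CCCc3cccnc32)CC1` gives 71% as the higher. Compound 3 `N[C@H]1CC[C@@H](N(C[C@H]2Cc3ccccc3CN2)[C@H]2CCCc3cccnc32)CC1` carries 4-aminocyclohexyl in place of the open chain of compound 2, on an amine nitrogen, a change that amounts to a group of 7 heavy atoms (6 carbon, 1 nitrogen; one six-membered non-aromatic ring of carbon only) in place of a group of 6 heavy atoms (5 carbon, 1 nitrogen; no ring), on an amine nitrogen overall. Going by the values given here, one measured step bears on this, in the opposite direction: a number 69 percentage points lower from compound 1 to compound 2 (beyond the scatter) when the ring group gave way to the chain. A large rise is therefore expected, and the estimated step is a number 58 percentage points higher from compound 2 to compound 3 (beyond the scatter) in this assay on this single precedent. Compound 3 is expected at 60% as an estimate, within a range from 35% to 82% for repeated measurements.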

Compound 3, percent of the compound remaining: 24%
Compound 3: the middle estimate sits 36 percentage points above what was measured, outside the stated range (below it).
By their numbers in this assay, from the lowest: compound 2; then compound 3; then compound 1.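

In this assay, the 4-aminocyclohexyl group on the amine nitrogen does not by itself restore the number, since its stereoisomer gives only a number 22 percentage points higher from compound 2 to compound 3 (beyond the scatter). The configuration of that ring carries a large part of the effect, with a number 47 percentage points lower from compound 1 to compound 3 (beyond the scatter). No change of atoms can account for this gap: the fact that compounds 1 and 3 differ only in the configuration as drawn

On these data alone, whether configuration matters as much for other ring groups on this nitrogen remains open, for instance a cyclohexyl carrying a hydroxyl in place of the amine. Also open, as far as these compounds go, is whether an open chain with a saturated carbon chain in place of the double bond would behave like compound 2.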